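Swapping the octyl chain for a dichlorophenyl ring

The source may hold more compounds than are shown below. What is called first, only, known or untested is meant among the compounds shown, and "the series" means these compounds.

Two amides on a shared core have been measured in a functional assay on SW1573 cells (Homo sapiens) for cytotoxicity, read by sulforhodamine B assay, with a stated time of 72 h; on this read-out higher numbers stand for weaker inhibition and lower numbers for stronger inhibition. Compound 1 `CCCCCCCCC(=O)Nc1ccn([C@@H]2CO[C@H](CO)O2)c(=O)n1` gives 276 nM and stands as the highest of the two numbers. Its nearest neighbour, compound 2 `CCCCCCCCCCCC(=O)Nc1ccn([C@@H]2CO[C@H](CO)O2)c(=O)n1`, gives 30 nM, and the step between them, propyl in place of hydrogen on a saturated chain carbon eight bonds along the chain from a carbonyl carbon, is a 9.2-fold lower number from compound 1 to compound 2 (0.96 log units; beyond the scatter).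

Compound 3 `O=C(Nc1ccn([C@@H]2CO[C@H](CO)O2)c(=O)n1)c1ccc(Cl)cc1Cl` is not yet measured. It differs from compound 1 by 2,4-dichlorophenyl in place of octyl on a carbonyl carbon. Among the compounds with values here, the one measured step bears only loosely on this change: it shows that a longer saturated chain at this position went with a lower number, whereas here the chain is removed altogether and a ring enters. Within the data shown here, no measured pair shows an aromatic group at this position, so the expectation rests on the direction of the chain step alone. Among the measured compounds shown here, the expected step is a 2.9-fold higher number from compound 1 to compound 3 (0.46 log units; beyond the scatter), a higher number than compound 1 because the only change that lowered the number, a 9.2-fold lower number from compound 1 to compound 2 (0.96 log units; beyond the scatter), lengthened the chain rather than replacing it. The estimate for compound 3 in this assay is 800 nM, with a range from 150 nM to 4000 nM.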

Compound 3, half-maximal inhibitory concentration: 14300 nM
Estimate against measurement, compound 3: 18-fold (1.25 log units) below, outside the stated range (above it).
By their numbers in this assay, from the lowest: compound 2; then compound 1; then compound 3.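

In this assay, within the data shown here, the exchange of octyl for 2,4-dichlorophenyl on the carbonyl carbon gives a 52-fold higher number from compound 1 to compound 3 (1.71 log units; beyond the scatter), a large rise at a position where the only earlier change had lowered the number. That earlier step, a 9.2-fold lower number from compound 1 to compound 2 (0.96 log units; beyond the scatter), varied only the length of a saturated chain, whereas this one shows that the kind of group matters: the leaving and entering groups have equal heavy-atom counts and neither carries a hydrogen-bond donor or acceptor, yet the numbers lie far apart. Nothing available explains the size of this rise.

With only one ring-bearing amide among the compounds shown, it remains open whether the higher number goes with the aromatic ring itself or with its two chlorine atoms, a question that an unsubstituted phenyl group would address. Also open, on these data alone, is whether a chain longer than that of compound 2, such as a pentadecyl chain, would continue the fall in the number seen from compound 1 to compound 2, or whether that trend ends.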